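This account rests on a few compounds, and the source may have more. Where it says the series, first, only, none or still open, it means among the compounds named here.

In a functional assay on K562 cells (Homo sapiens) for cytotoxicity, read by ELISA, with a stated time of 4 days (on this read-out higher numbers stand for weaker inhibition and lower numbers for stronger inhibition), compound 1 (`Cc1ccsc1-c1cc(-c2ccco2)cc(-c2ccccc2Cl)n1`) gives 25400 nM, compound 2 (`Cc1ccsc1-c1cc(-c2ccco2)cc(-c2ccc(Cl)cc2)n1`) gives 20700 nM and compound 3 (`Cc1ccc(-c2cc(-c3ccoc3)cc(-c3ccc(Cl)s3)n2)o1`) gives 12700 nM. Compound 3 therefore stands within the usual scatter of both other compounds, and the three numbers cannot be ranked. Compound 4 (`Cc1ccc(-c2cc(-c3ccoc3)cc(-c3ccc(Cl)s3)n2)cc1`) differs from compound 3 by having 4-methylphenyl in place of 5-methylfuran-2-yl on an aromatic carbon. Among the measured compounds shown here, no measured step makes this exchange. For the measured compounds named here, the only step available, a 1.2-fold lower number from compound 1 to compound 2 (0.09 log units; within the scatter), has 4-chlorophenyl in place of 2-chlorophenyl and lies within the scatter, so it bears on the new change only indirectly. It offers no support for a sizeable shift in either direction, and no step beyond the scatter is expected in this assay. The expected change is small, a 1.0-fold higher number from compound 3 to compound 4 (0.01 log units; within the scatter), and the direction is not meaningful. The estimate for compound 4 is 13000 nM, with an expected range of 5500 nM to 30000 nM.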

Compound 4, half-maximal inhibitory concentration: 17900 nM
Compound 4: the middle estimate sits 1.4-fold (0.14 log units) below what was measured; the range from low to high includes it.
By their numbers in this assay, from the lowest: compounds 3, 4, 2 and 1 (each within the scatter of the next).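

In this assay, the exchange of 5-methylfuran-2-yl for 4-methylphenyl on the aromatic carbon next to the ring nitrogen gives a 1.4-fold higher number from compound 3 to compound 4 (0.15 log units; within the scatter), and this lies within the scatter. Among the compounds shown here, this is the first reading at this position, since the earlier step concerned only 4-chlorophenyl against 2-chlorophenyl: here a five-membered aromatic ring with a hetero atom and a hydrogen-bond acceptor gives way to a six-membered aromatic ring of carbon only, with no detectable effect on the number. Nothing available here bears on why the read-out stays within the scatter.

On these data alone, whether a different kind of group at this position, such as an aliphatic amine or a carboxylic acid, would produce a step beyond the scatter remains open. As far as these compounds go, what the 5-chlorothiophen-2-yl and furan-3-yl groups contribute also remains open.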